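A few compounds are considered here, and "the series" means these few. Any claim that something is new, unique, unknown or untested is made for them only; others in the source may bear on it.

Two compounds of a shared core were measured in an ADME assay on Raji cells (Homo sapiens) for cytotoxicity, read by CellTiter-Glo and resazurin assay, with a stated time of 72 h; on this read-out higher numbers stand for an effect only at larger amounts of compound and lower numbers for an effect already at smaller amounts. Compound 1 `CC(C)N(Cc1cccc(OCCCCCC(=O)O)c1)C(=O)c1ccc(-c2ccncc2)cc1` carries a pyridin-4-yl. In this assay compound 1 reaches only the limit of > 26000 nM. Compound 2 `CCOC(=O)CCCCCOc1cccc(CN(C(=O)c2ccc(-c3ccc4ccccc4c3)cc2)C(C)C)c1` carries a naphthalen-2-yl instead. In this assay compound 2 likewise reaches only the limit of > 26000 nM. Compound 2 thus stands where every value shown stands, namely at the limit of > 26000 nM in this assay, at which 2 of the 2 values shown sit, and no number separates it from compound 1.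

Compound 3 `CCOC(=O)CCCCCOc1cccc(CN(C(=O)c2ccc(-c3ccncc3)cc2)C(C)C)c1` differs from compound 2 by pyridin-4-yl in place of naphthalen-2-yl on an aromatic carbon. Among the compounds with values here, no measured pair isolates this change in this assay. Compound 1 already carries a pyridin-4-yl and still gives only the limit of > 26000 nM. The step from compound 2 to compound 3 is therefore expected to be none beyond the scatter, a step that the limit leaves unreadable from compound 2 to compound 3. Compound 3 is estimated at 40000 nM, within 15000 nM to 120000 nM, and is most likely to be reported again only as a limit.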

Compound 3, half-maximal effective concentration: > 26000 nM
Compound 3 ended at the assay's limit; the forecaster's own chance of this, stated with the estimate: 85%; the middle value is on the limit's open side.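

Neither the step to compound 3 from compound 2 nor the step to compound 3 from compound 1 can be read, since all three compounds sit at one limit in this assay: the limit of > 26000 nM in this assay, at which 3 of the 3 values shown sit.

The compounds shown leave open whether pyridin-4-yl, naphthalen-2-yl or the ethyl makes any difference in this assay.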